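The source may report more compounds than this note shows. Statements on the series, on what has been measured and on what is new or still open speak of the compounds shown alone.

Of the compounds shown here, two of this set have been tested in a functional assay on the whole organism with Rattus norvegicus as the target, in the glucose tolerance test; on this read-out lower numbers stand for an effect already at smaller amounts and higher numbers for an effect only at larger amounts of compound. Compound 1, with the structure `CCCCCCCCCCCCCCCCCCC1(C(=O)OC)CO1`, gives a minimum effective dose of 10 mg/kg in this assay. Compound 2, with the structure `CCCCC/C=C/CCCCCCCCCC1(C(=O)OC)CO1`, gives 10 mg/kg in this assay, which is level with compound 1 at the digits shown; the two values sit within the usual scatter of each other, so nothing can be said about an order between them.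

Compound 3, with the structure `CCCCCCCCCCCCC1(C(=O)OC)CO1`, has not yet been measured in this assay. It differs from compound 2 in one place: propyl in place of hept-1-en-1-yl on a saturated chain carbon, nine bonds along the chain from a saturated ring carbon. Among the measured compounds shown here, no measured pair shows a change of this kind, so the size of the step cannot be read from the numbers in hand. The shortening of the chain is an uncharted move here, and a modest loss of effect, or none beyond the scatter, is what the author expects; the step of a 1.5-fold higher number from compound 2 to compound 3 (0.18 log units; within the scatter) is the estimate. Compound 3 is therefore expected to give about 15 mg/kg in this assay, with a range from 5 mg/kg to 50 mg/kg.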

Compound 3, minimum effective dose: 5 mg/kg
Compound 3: middle estimate off by 3.0-fold (0.48 log units), on the high side, and the stated range covers the measured number.
By their numbers in this assay, from the lowest: compounds 3, 1 and 2 (each within the scatter of the next).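

In this assay, propyl in place of hept-1-en-1-yl on a saturated chain carbon, nine bonds along the chain from a saturated ring carbon, comes to a 2.0-fold lower number from compound 2 to compound 3 (0.30 log units; within the scatter), while hydrogen in place of hexyl on a saturated chain carbon comes to a 2.0-fold lower number from compound 1 to compound 3 (0.30 log units; within the scatter). Compounds 1 and 2 alone could not show it, but the chain can be substantially shortened, from either the saturated or the unsaturated compound, without the minimum effective dose moving beyond the scatter. Nothing at hand explains why the shorter chain keeps the effect.

The compounds shown leave open how far this shortening can go, since a much shorter chain such as a butyl group, or a longer one than those shown, might or might not hold the same dose. They also leave open whether the chain accepts a carboxylic acid, an amine or a phenyl ring, and whether a carboxylic acid in place of the methyl ester on the shared core gives a similar dose.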